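Phenyl to 4-hydroxyphenyl on compound 3

The compounds below may be only part of what the source reports. "The series", "measured", "known", "first", "only" and "open" are said of these compounds alone.

Measured in a functional assay on A2780 cells (Homo sapiens) for inhibition, read by sulforhodamine B assay (on this read-out higher numbers stand for weaker inhibition of growth and lower numbers for stronger inhibition of growth), so far
- compound 1 `c1ccc(-c2ccc(-c3ccc(-c4nc5ccccc5[nH]4)cc3)cc2)cc1` gives 32100 nM
- compound 2 `Cc1ccc2[nH]c(-c3ccc(-c4ccc(-c5ccc(N(C)C)cc5)cc4)cc3)nc2c1` gives 2210 nM
- compound 3 `Oc1cccc2[nH]c(-c3ccc(-c4ccc(-c5ccccc5)cc4)cc3)nc12` gives 41000 nM

Compound 3 (41000 nM) lies within the scatter of compound 1 and well above compound 2 (2210 nM) on these numbers. Compound 4 `Oc1ccc(-c2ccc(-c3ccc(-c4nc5c(O)cccc5[nH]4)cc3)cc2)cc1` differs from compound 3 by one change (hydroxy in place of hydrogen on an aromatic carbon), phenyl to 4-hydroxyphenyl, hydroxy in place of hydrogen on an aromatic carbon. Among the measured compounds shown here, the only measured step of this kind, at another place, is a 1.3-fold higher number from compound 1 to compound 3 (0.11 log units; within the scatter) and stays within the scatter. Compound 2 differs in more than one place, so it only hints that a lower number is possible. The expected, estimated step (a 2.3-fold lower number from compound 3 to compound 4 (0.36 log units; beyond the scatter)) is small and toward a lower number in this assay for this series. Compound 4 is estimated at 18000 nM with an expected range from 5000 nM to 50000 nM in this read-out.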

Compound 4, concentration for 50% growth inhibition: 2920 nM
For compound 4 the middle estimate is 6.2-fold (0.79 log units) above the measured one, outside the stated range (below it).
By their numbers in this assay, from the lowest: compounds 2 and 4 (each within the scatter of the next); then compounds 1 and 3 (each within the scatter of the next).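

In this assay the hydroxy para to a large group gives a large step (a 14-fold lower number from compound 3 to compound 4 (1.15 log units; beyond the scatter)). The same change at the other place stays within the scatter (a 1.3-fold higher number from compound 1 to compound 3 (0.11 log units; within the scatter)), so in this series its effect on the read-out differs with where it sits. Nothing shown accounts for this difference.

From the compounds shown here alone, it remains open whether a methoxy or a carboxylic acid at this place would give a step of similar size. Going by these compounds, it also remains open whether the step depends on the hydroxy already present in compound 3.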